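Aryl amide variation on a shared core: compound 4

The compounds below may be only part of what the source reports. "The series", "measured", "known", "first", "only" and "open" are said of these compounds alone.

Measured compounds in a functional assay on MCF7 cells (Homo sapiens) for antiproliferative activity, read by MTT assay, with a stated time of 72 h; a higher number here means a weaker inhibitor, a lower number a stronger inhibitor:
- compound 1 `O=C(Nc1ccc(Cl)c(-c2nnc3c(Cl)cccn23)c1)c1ccccn1` gives 96400 nM
- compound 2 `O=C(Nc1ccc(Cl)c(-c2nnc3c(Cl)cccn23)c1)c1cccc(Cl)c1` gives 71900 nM
- compound 3 `CS(=O)(=O)c1ccc(C(=O)Nc2ccc(Cl)c(-c3nnc4c(Cl)cccn34)c2)cc1` gives 94200 nM

All three compounds share the same core and differ only in the aryl group on the carbonyl carbon of the amide. The steps between them are small: a 1.3-fold lower number from compound 1 to compound 2 (0.13 log units; within the scatter) and a 1.0-fold lower number from compound 1 to compound 3 (0.01 log units; within the scatter) both fall within the scatter, as does a 1.3-fold higher number from compound 2 to compound 3 (0.12 log units; within the scatter). Compound 3 therefore stands among three numbers that cannot be told apart; it sits close to compound 1 and somewhat further from compound 2, but neither gap is beyond the scatter.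

Compound 4 `Cc1cc(Cl)ccc1C(=O)Nc1ccc(Cl)c(-c2nnc3c(Cl)cccn23)c1` has not yet been measured. Its difference from compound 3 is 4-chloro-2-methylphenyl in place of 4-(methylsulfonyl)phenyl on a carbonyl carbon. The step from compound 2 to compound 3, in which a chlorophenyl gave way to a methylsulfonylphenyl, bears most directly on this change, and that step was within the scatter. Reversing it, with a chlorine again on the aryl group and a methyl added, is expected to yield a step of similar size, so compound 4 is estimated at a 1.3-fold lower number from compound 3 to compound 4 (0.10 log units; within the scatter). The expected value for compound 4 in this assay is 75000 nM, with a range from 35000 nM to 160000 nM.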

Compound 4, half-maximal inhibitory concentration: > 100000 nM
Compound 4: only a limit was reported (the forecaster's own chance of this, stated with the estimate: 20%); at least 1.3-fold (0.12 log units) between middle value and limit.
By their numbers in this assay, from the lowest: compounds 2, 3 and 1 (each within the scatter of the next). At a limit, above all of these: compound 4.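

In this assay, compound 4 carries a limit and not a number, and it is the only compound shown that sits there: the limit of > 100000 nM in this assay, at which 1 of the 4 values shown sits.

Its steps can therefore be read only as floors, all of which lie within the scatter: there is an at least 1.0-fold higher number from compound 3 to compound 4 (0.02 log units; that floor lies within the scatter), an at least 1.3-fold higher number from compound 2 to compound 4 (0.14 log units; that floor lies within the scatter) and an at least 1.0-fold higher number from compound 1 to compound 4 (0.01 log units; that floor lies within the scatter). What compound 4 adds is that 4-chloro-2-methylphenyl on a carbonyl carbon whose other neighbour is an amide-type nitrogen, a group with no hydrogen-bond acceptors in place of the 4-(methylsulfonyl)phenyl with its two, gives no lower number than the earlier aryl groups, so none of the four compounds separates from the others as a stronger inhibitor.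

As far as these compounds go, how far the true value of compound 4 lies past its limit stays open, and with it whether this change has any effect beyond the scatter. Also open is whether an aliphatic amine, a carboxylic acid or a longer alkyl chain on this carbonyl carbon, in place of the aryl groups shown, would bring the number down beyond the scatter.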